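Trifluoromethoxy in place of fluoro on the shared core

The compounds below may be only part of what the source reports. "The series", "measured", "known", "first", "only" and "open" are said of these compounds alone.

In a functional assay on Gurav cells (Homo sapiens) for inhibition, read by sulforhodamine B assay (a lower number here means a stronger inhibitor of growth, a higher number a weaker inhibitor of growth), compound 1 `Cc1ccc2[nH]c(-c3ccc(-c4ccc(-c5ccc(N(C)C)cc5)cc4)cc3)nc2c1` gives 6240 nM and compound 2 `Cc1ccc2[nH]c(-c3ccc(-c4ccc(-c5ccc(F)cc5)cc4)cc3)nc2c1` gives 16500 nM. Compound 2 therefore holds the higher of the two numbers and is the weaker growth inhibitor of the pair. Compound 3 `Cc1ccc2[nH]c(-c3ccc(-c4ccc(-c5ccc(OC(F)(F)F)cc5)cc4)cc3)nc2c1` carries trifluoromethoxy in place of fluoro on an aromatic carbon, para to a large group: trifluoromethoxy in place of fluoro on an aromatic carbon. Within the data shown here, only one measured step bears on this change, and it alters the same place: a 2.6-fold higher number from compound 1 to compound 2 (0.42 log units; beyond the scatter). Among the measured compounds shown here, no measured compound carries trifluoromethoxy, so that modest step is only a rough guide to size. On the strength of it, a shift no larger is expected in this assay, and most likely none beyond the scatter. The expected change is a 1.2-fold lower number from compound 2 to compound 3 (0.07 log units; within the scatter). Compound 3 is estimated at 14000 nM, with an expected range of 5500 nM to 38000 nM.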

Compound 3, concentration for 50% growth inhibition: 11000 nM
The estimate for compound 3 lay 1.3-fold (0.10 log units) above the measured number, and the stated range covers the measured number.
By their numbers in this assay, from the lowest: compounds 1, 3 and 2 (each within the scatter of the next, the first and the last beyond it).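

At this aromatic carbon, para to a large group, the single fluorine gives way to the much larger trifluoromethoxy with no change that this assay can resolve: the step is a 1.5-fold lower number from compound 2 to compound 3 (0.18 log units; within the scatter). Compound 3 also cannot be separated from the dimethylamino compound (a 1.8-fold higher number from compound 1 to compound 3 (0.25 log units; within the scatter)), so it sits within the scatter of both neighbours, and only the earlier step between compound 1 and compound 2 remains beyond it. Nothing shown here explains these numbers.

The compounds shown leave open whether a carboxylic acid, a primary amine or a longer alkyl chain on this carbon would move the number further than any of these three groups. They also leave open whether a group at another place on the shared core would matter more.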